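The source may hold more compounds than are shown below. What is called first, only, known or untested is meant among the compounds shown, and "the series" means these compounds.

Measured so far in an assay for inhibition of protein disulfide-isomerase (Homo sapiens), with a stated time of 1 h; a higher number here means a weaker inhibitor, a lower number a stronger inhibitor:
compound 1, `Oc1cccc(C(Nc2ccccn2)c2ccc3cccnc3c2O)c1Cl`: 370 nM
compound 2, `Oc1ccc2[nH]ncc2c1C(c1ccc(-n2cccc2)cc1)N1CCCCC1`: 290 nM
compound 3, `Oc1ccc2ccncc2c1C(c1ccc(F)cc1)N1CCCCC1`: 10200 nM

Compound 1 stands second highest of the three numbers. Its nearest neighbour is compound 2, whose number sits within the scatter of that of compound 1, so the two are not ordered against each other. The gap to compound 3 is beyond the scatter, compound 3 carrying by far the highest number of the set. Among the compounds with values here, no pair among the measured compounds differs in a single place, so no measured step is at hand to lean on.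

Compound 4, `Cc1ccc(C(Nc2ccccn2)c2ccc3cccnc3c2O)cc1`, differs from compound 1 by 4-methylphenyl in place of 2-chloro-3-hydroxyphenyl on a saturated chain carbon bound to an aromatic carbon and a nitrogen on an aromatic ring. The change removes the hydroxyl and the chlorine counted in the leaving group and brings in a group with neither donor nor acceptor. Without a measured step of this kind, the expectation is a move to a higher number than compound 1 in this assay, by a modest step beyond the scatter rather than one approaching the gap to compound 3. Compound 4 is estimated at 1500 nM in this assay, with a range of 400 nM to 6000 nM. That estimate corresponds to an expected step of a 4.1-fold higher number from compound 1 to compound 4 (0.61 log units; beyond the scatter).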

Compound 4, half-maximal inhibitory concentration: 460 nM
Compound 4: middle estimate off by 3.3-fold (0.51 log units), on the high side; the measured number falls inside the stated range.
By their numbers in this assay, from the lowest: compounds 2, 1 and 4 (each within the scatter of the next); then compound 3.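

In this assay, within the data shown here, the swap at this saturated chain carbon gives a 1.2-fold higher number from compound 1 to compound 4 (0.09 log units; within the scatter), so this is the first measured single-place step. At this position, the shared core carries either 2-chloro-3-hydroxyphenyl or 4-methylphenyl, a group with neither donor nor acceptor, with no readable difference in the number. The hydroxyl and the chlorine therefore show no measurable contribution when they leave together, though no data explain this result.

As far as these compounds go, because both groups leave in one change, the effect of the hydroxyl alone and of the chlorine alone remains open, and the two could offset each other. Also open, from the compounds shown here alone, is whether the number holds with a carboxylic acid or an amine on the phenyl ring, or with a saturated cyclohexyl ring in its place.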